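Moving the chlorine on the cinnamamide ring

A few compounds are considered here, and "the series" means these few. Any claim that something is new, unique, unknown or untested is made for them only; others in the source may bear on it.

Measured so far:
compound 1, `CCCc1cc(N)c2cc(NC(=O)/C=C/c3ccc(C(C)(C)C)cc3)ccc2n1`: 910 nM
compound 2, `CCCc1cc(N)c2cc(NC(=O)/C=C/c3ccccc3Cl)ccc2n1`: 500 nM

Both were tested in a functional assay on HEK293 cells for activation of melanin-concentrating hormone receptor 1 (Homo sapiens), read by inositol phosphate accumulation; on this read-out lower numbers stand for an effect already at smaller amounts and higher numbers for an effect only at larger amounts of compound. Compound 2 gives the lower of the two numbers, yet its gap to compound 1 lies within the scatter, so neither can be called the more potent. Compound 3, `CCCc1cc(N)c2cc(NC(=O)/C=C/c3ccc(Cl)cc3)ccc2n1`, differs from compound 2 only in the ring at the end of the double-bonded chain: 4-chlorophenyl in place of 2-chlorophenyl on a double-bonded chain carbon bound to a double-bonded chain carbon. Among the measured compounds shown here, no measured pair shows what such a shift does here, so the step of a 1.4-fold higher number from compound 2 to compound 3 (0.15 log units; within the scatter) is expected to stay within the scatter, in no firm direction. In this assay compound 3 is estimated at 700 nM, with a range from 250 nM to 2000 nM.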

Compound 3, half-maximal effective concentration: 96 nM
For compound 3 the middle estimate is 7.3-fold (0.86 log units) above the measured one; measured number outside the range, below it.
By their numbers in this assay, from the lowest: compound 3; then compounds 2 and 1 (each within the scatter of the next).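

In this assay, 4-chlorophenyl in place of 2-chlorophenyl gives a 5.2-fold lower number from compound 2 to compound 3 (0.72 log units; beyond the scatter), so with the same atoms, where the chlorine sits on this ring clearly changes the number. Chloro in place of tert-butyl on an aromatic carbon gives a 9.5-fold lower number from compound 1 to compound 3 (0.98 log units; beyond the scatter), showing that the choice of group on that carbon matters as well. Nothing available here explains either step. From the compounds shown here alone, whether fluoro, methoxy or an amine on that same aromatic carbon would match chloro remains open.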